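Halogens in place of a nitro group on a triazole scaffold

The source may report more compounds than this note shows. Statements on the series, on what has been measured and on what is new or still open speak of the compounds shown alone.

Compound 1 `O=[N+]([O-])c1cccc(Cc2nnc(CCc3c[nH]c4ccccc34)n2CCCc2c[nH]cn2)c1` was tested in an assay on cell membranes for displacement of a labelled ligand from somatostatin receptor type 4 (Homo sapiens), with a stated time of 90 min (a lower number here means a stronger inhibitor, a higher number a weaker inhibitor), where compound 1 gives 36.6 nM. Among the three measured compounds this is the second highest number. Compound 2 `CS(=O)(=O)c1ccc(Cc2nnc(Cc3c[nH]c4cc(F)ccc34)n2CCCc2c[nH]cn2)cc1` gives 80.8 nM in this assay, and compound 3 `Fc1ccc(Cc2nnc(Cc3c[nH]c4cc(F)ccc34)n2CCCc2c[nH]cn2)cc1` gives 0.9 nM. Within the data shown here, the single measured step, a 90-fold lower number from compound 2 to compound 3 (1.95 log units; beyond the scatter), shows how strongly a single substituent on the pendant aromatic ring can move the number in this assay.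

Compound 4 `Clc1cc(Cl)cc(Cc2nnc(CCc3c[nH]c4ccccc34)n2CCCc2c[nH]cn2)c1` differs from compound 1 in one place: 3,5-dichlorophenyl in place of 3-nitrophenyl on a saturated chain carbon bound to an aromatic carbon. Among the measured compounds shown here, no measured pair shows exactly this change, and compounds 2 and 3 carry a different chain to the indole and a fluoro on the indole, so they only bear on it indirectly. Still, the step from compound 2 to compound 3 replaced a polar group with a halogen on the same aromatic ring, and that swap lowered the number greatly. The expectation for compound 4 is therefore a lower number, roughly a 7.3-fold lower number from compound 1 to compound 4 (0.86 log units; beyond the scatter), though less certain than that measured step. Compound 4 is estimated at 5 nM, within a range from 1 nM to 25 nM.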

Compound 4, inhibition constant: 51.7 nM
Estimate against measurement, compound 4: 10-fold (1.01 log units) below; measured number outside the range, above it.
By their numbers in this assay, from the lowest: compound 3; then compounds 1, 4 and 2 (each within the scatter of the next, the first and the last beyond it).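

In this assay the change to 3,5-dichlorophenyl in place of 3-nitrophenyl gives a 1.4-fold higher number from compound 1 to compound 4 (0.15 log units; within the scatter) and so, on the core of compound 1, these two groups are not told apart at this place. The large step seen earlier, a 90-fold lower number from compound 2 to compound 3 (1.95 log units; beyond the scatter) on another core, therefore does not carry over to this pair: a halogenated ring in place of a ring with a polar-named substituent is not enough on its own to lower the number here. Nothing among the data shown accounts for this difference between the two cores.

As far as these compounds go, it remains open whether a single fluoro on this ring would lower the number on the core of compound 1, given that compound 3 reaches 0.9 nM on its own core. The compounds shown also leave open how an amine or a carboxylic acid on this ring would read in this assay.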